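The source may hold more compounds than are shown below. What is called first, only, known or untested is meant among the compounds shown, and "the series" means these compounds.

Measured so far:
- compound 1, `N=C(N)c1ccc(/C=C2/CC/C(=C\c3ccc(C(=N)N)cc3)C2=O)cc1`: 730 nM
- compound 2, `COC(=O)C1C/C(=C/c2ccc(C(=N)N)cc2)C(=O)/C(=C/c2ccc(C(=N)N)cc2)C1`: 224 nM

Notes on the series. In an assay on isolated protein for inhibition of serine protease 1 (Bos taurus) (a lower number here means a stronger inhibitor, a higher number a weaker inhibitor), compound 1 gives 730 nM. Compound 2 carries the methyl ester on the shared core and in this assay gives 224 nM, the lowest of the two numbers recorded; its gap to compound 1 lies beyond the usual scatter.

The next member is compound 3, `COC(=O)C1C/C(=C/c2ccc(C(=N)N)cc2)C(=O)/C(=C\c2ccc(C(=N)N)cc2)C1`. Its difference from compound 2 is the two compounds have the same atoms and bonds; at least one stereo element is drawn with a configuration in one of them and without one in the other: 1 of 5 stereo elements differ; a double bond is drawn E in compound 2 and Z in compound 3. For the measured compounds named here, no measured pair shows what switching one double bond from E to Z does, so the direction of the step rests on no precedent here. A moderate weakening is assumed, as the shape of the core changes while nothing enters or leaves. For compound 3 the expected value is 500 nM, within 150 nM to 1800 nM. The step this estimate implies is a 2.2-fold higher number from compound 2 to compound 3 (0.35 log units; beyond the scatter), possibly not beyond the scatter.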

Compound 3, inhibition constant: 100 nM
Compound 3: the middle estimate sits 5.0-fold (0.70 log units) above what was measured; measured number below the stated range.
By their numbers in this assay, from the lowest: compound 3; then compound 2; then compound 1.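

In this assay, a change of geometry at one double bond, with nothing entering or leaving, gives a 2.2-fold lower number from compound 2 to compound 3 (0.35 log units; beyond the scatter). For the compounds shown here, this is the first pair to isolate such a change, and it shows that the drawn configuration at this double bond alone can shift the number beyond the scatter, with the Z form giving the lower number in this pair. The step is modest and rests on this single pair, and its reading carries one qualification: the fact that one of compounds 2 and 3 is drawn with a defined configuration and the other without, at the place where they differ

The compounds shown leave open whether the other double bond responds in the same way to a switch from E to Z. They also leave open whether the Z form keeps its lower number when the methyl ester gives way to a carboxylic acid or a primary amide.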